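The source may hold more compounds than are shown below. What is called first, only, known or untested is meant among the compounds shown, and "the series" means these compounds.

- compound 1 `FC(F)(F)c1cccc(NN=C2C(Cl)=C(Cl)C(Cl)=C2Cl)c1` at 110 nM 
- compound 2 `CC(C)(C)C(=O)NN=C1C(Cl)=C(Cl)C(Cl)=C1Cl` at 90 nM 

In a functional assay on RPMI-8226 cells (Homo sapiens) for cytotoxicity, read by MTT assay, with a stated time of 48 h (on this read-out higher numbers stand for weaker inhibition and lower numbers for stronger inhibition), compound 1 gives 110 nM and stands within the scatter of compound 2, which gives 90 nM on the same read-out. The two cannot be told apart.

The next compound is compound 3 `COc1cccc(NN=C2C(Cl)=C(Cl)C(Cl)=C2Cl)c1`, which has methoxy in place of trifluoromethyl on an aromatic carbon, meta to a large group (methoxy in place of trifluoromethyl on an aromatic carbon). Among the measured compounds shown here, no measured pair shows this change, so the data offer no step to scale it by. In this assay no step beyond the scatter is expected, in either direction. The expected move is small (a 1.1-fold higher number from compound 1 to compound 3 (0.04 log units; within the scatter)). For compound 3 the estimated value is 120 nM with an expected range from 40 nM to 360 nM on this read-out.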

Compound 3, half-maximal inhibitory concentration: > 3000 nM
Compound 3: no number, only a limit; the forecaster's own chance of this, stated with the estimate: 2%; middle value at least 25-fold (1.39 log units) from the limit.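

Methoxy in place of trifluoromethyl on an aromatic carbon, meta to a large group, gives an at least 27-fold higher number from compound 1 to compound 3 (1.43 log units; beyond the scatter) in this assay, so activity in this series depends strongly on the group at this place, which compounds 1 and 2 alone could not show. For compound 3, > 3000 nM is a limit of the assay and not a number. The step therefore gives only a minimum size, and how far compound 3 actually lies from compound 1 stays unknown: the limit of > 3000 nM in this assay, at which 1 of the 3 values shown sits.

A single pair cannot separate the departure of trifluoromethyl from the arrival of methoxy as the source of the step. Going by these compounds, whether a nitrile, a chlorine or plain hydrogen at this place keeps the value of compound 1 or follows compound 3 remains open.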